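The source may report more compounds than this note shows. Statements on the series, on what has been measured and on what is new or still open speak of the compounds shown alone.

Measured compounds:
compound 1 `COc1ccc(-c2cc(/C=C/C(=O)c3ccc(N)cc3)[nH]n2)cc1` — 2140 nM
compound 2 `COc1cc(-c2cc(/C=C/C(=O)c3ccc(N)cc3)[nH]n2)cc(OC)c1OC` — 2060 nM
compound 3 `COc1cc(-c2cc(/C=C/C(=O)c3ccc(Cl)c(Cl)c3)[nH]n2)cc(OC)c1OC` — 8650 nM

All three were run in a functional assay on MDA-MB-231 cells (Homo sapiens) for inhibition, read by sulforhodamine B assay, with a stated time of 48 h; on this read-out lower numbers stand for stronger inhibition of growth and higher numbers for weaker inhibition of growth. Compound 3 stands at the highest number of the three; compound 1 lies nearest and compound 2 furthest, both beyond the scatter below it. Among the compounds with values here, the only single-point step available is a 4.2-fold higher number from compound 2 to compound 3 (0.62 log units; beyond the scatter), which shows the move away from an aminophenyl at the carbonyl carbon to a dihalogenated phenyl costing a modest amount. Compound 4 `COc1cc(-c2cc(/C=C/C(=O)c3ccc(F)c(F)c3)[nH]n2)cc(OC)c1OC` carries the change (3,4-difluorophenyl in place of 3,4-dichlorophenyl on a carbonyl carbon). Within the data shown here, no measured pair swaps one halogen pair for another, so the step from compound 3 cannot be read off a precedent; the step from compound 2 to compound 3 only places compound 3 as the reference. Without a direct analogue, the expectation for this assay is a change no larger than the scatter in either direction, with a wide band. Compound 4 is therefore estimated at 6500 nM, within 2500 nM to 17000 nM, meaning an expected step of a 1.3-fold lower number from compound 3 to compound 4 (0.12 log units; within the scatter).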

Compound 4, concentration for 50% growth inhibition: 1640 nM
Beside the measured number, compound 4's estimate is 4.0-fold (0.60 log units) above it; measured number outside the range, below it.
By their numbers in this assay, from the lowest: compounds 4, 2 and 1 (each within the scatter of the next); then compound 3.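

In this assay the choice of halogen pair on the phenyl at the carbonyl carbon matters: a 5.3-fold lower number from compound 3 to compound 4 (0.72 log units; beyond the scatter) for 3,4-difluorophenyl in place of 3,4-dichlorophenyl, so the two dihalogenated rings are not interchangeable here. The earlier loss, a 4.2-fold higher number from compound 2 to compound 3 (0.62 log units; beyond the scatter) on leaving 4-aminophenyl, therefore does not extend to every dihalogenated phenyl. With a 1.3-fold lower number from compound 2 to compound 4 (0.10 log units; within the scatter) printed as within the scatter, 3,4-difluorophenyl matches 4-aminophenyl at this position, and the amine is not required to hold the number. Nothing available here accounts for the difference between the two halogen pairs.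

As far as these compounds go, whether a single fluorine, a trifluoromethyl or a carboxylic acid on this phenyl would hold the number remains open. From the compounds shown here alone, it is also open whether the 3,4-difluorophenyl result carries over to the core of compound 1.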